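Compound 3: benzoyl in place of benzyloxycarbonyl

The source may hold more compounds than are shown below. What is called first, only, known or untested is meant among the compounds shown, and "the series" means these compounds.

For the measured compounds named here, in a functional assay on A549 cells (Homo sapiens) for inhibition, read by CCK-8 assay, with a stated time of 48 h (on this read-out lower numbers stand for stronger inhibition of growth and higher numbers for weaker inhibition of growth), compound 1 (`O=C(CCCSC[C@H](NC(=O)OCc1ccccc1)C(=O)Nc1ccccc1)NO`) gives 3500 nM and compound 2 (`O=C(CCCSC[C@H](NC(=O)OCc1ccccc1)C(=O)Nc1cccc2ccccc12)NO`) gives 5300 nM so compound 1 stands within the scatter of its only measured neighbour. Compound 3 (`O=C(CCCSC[C@H](NC(=O)c1ccccc1)C(=O)Nc1ccccc1)NO`) carries phenyl in place of benzyloxy on a carbonyl carbon. Going by the values given here, the only measured step (a 1.5-fold higher number from compound 1 to compound 2 (0.18 log units; within the scatter)) is a change on an amide-type nitrogen and stays within the scatter. Among the compounds with values here, no measured step covers the carbonyl change, so the basis is thin. For compound 3 the expected step is small (a 1.1-fold higher number from compound 1 to compound 3 (0.06 log units; within the scatter)) with no shift beyond the scatter expected in either direction. Compound 3 is estimated at 4000 nM (expected range 1700 nM to 10000 nM).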

Compound 3, concentration for 50% growth inhibition: 4700 nM
Beside the measured number, compound 3's estimate is 1.2-fold (0.07 log units) below it, within the range that was stated.
By their numbers in this assay, from the lowest: compounds 1, 3 and 2 (each within the scatter of the next).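

In this assay, for the compounds shown here, phenyl in place of benzyloxy on a carbonyl carbon gives a 1.3-fold higher number from compound 1 to compound 3 (0.13 log units; within the scatter), the first measured change at this position. Going from benzyloxy to phenyl removes a hydrogen-bond acceptor and takes the group from 8 heavy atoms to 6, with no difference readable beyond the scatter. No available evidence bears on this result.

Still open, on these data alone, is whether an amine or a longer alkyl chain on this carbonyl carbon would move the number beyond the scatter.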